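Replacing 2,6-dimethoxyphenyl with 2,4-dichlorophenyl: a small step expected

The source may hold more compounds than are shown below. What is called first, only, known or untested is meant among the compounds shown, and "the series" means these compounds.

Of the compounds shown here, three that share one core have been tested in a functional assay on OVCAR-4 cells (Homo sapiens) for inhibition, read by sulforhodamine B assay, with a stated time of 48 h; on this read-out higher numbers stand for weaker inhibition of growth and lower numbers for stronger inhibition of growth. Compound 1 `O=C(Cc1csc2nc(-c3ccc(Br)cc3)cn12)N/N=C/c1ccccc1` gives 46800 nM. Compound 3 `COc1cccc(OC)c1/C=N/NC(=O)Cc1csc2nc(-c3ccc(Br)cc3)cn12` gives 28200 nM, and these two values lie within the scatter of each other, so the pair cannot be ranked. Compound 2 `O=C(Cc1csc2nc(-c3ccc(Br)cc3)cn12)N/N=C/c1ccc(O)cc1` is reported only as a limit, < 100000 nM. That limit leaves a step that the limit leaves unreadable from compound 1 to compound 2 and a step that the limit leaves unreadable from compound 2 to compound 3, so neither step can be used for sizing.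

The next compound is compound 4 `O=C(Cc1csc2nc(-c3ccc(Br)cc3)cn12)N/N=C/c1ccc(Cl)cc1Cl`, which carries 2,4-dichlorophenyl in place of 2,6-dimethoxyphenyl on a carbon with a double bond to nitrogen. Within the data shown here, only one readable step bears on this place, a 1.7-fold lower number from compound 1 to compound 3 (0.22 log units; within the scatter), where 2,6-dimethoxyphenyl replaced phenyl. That earlier change stayed within the scatter. Among the measured compounds shown here, no tested compound carries chlorine on this group, so the evidence is thin and the range must stay wide. On this basis, no change beyond the scatter is expected in this assay. The expected step is a 1.2-fold higher number from compound 3 to compound 4 (0.09 log units; within the scatter). For compound 4 the estimated value is 35000 nM, with an expected range from 14000 nM to 85000 nM.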

Compound 4, concentration for 50% growth inhibition: 37200 nM
Compound 4: middle estimate off by 1.1-fold (0.03 log units), on the low side; the range from low to high includes it.
By their numbers in this assay, from the lowest: compounds 3, 4 and 1 (each within the scatter of the next).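

In this assay, the place on a carbon with a double bond to nitrogen now also holds 2,4-dichlorophenyl, the first chlorine-bearing group shown there, and the readable steps are a 1.3-fold higher number from compound 3 to compound 4 (0.12 log units; within the scatter) and a 1.3-fold lower number from compound 1 to compound 4 (0.10 log units; within the scatter). Exchanging 2,6-dimethoxyphenyl, with 2 hydrogen-bond acceptors, for 2,4-dichlorophenyl, with 0, therefore gives no readable difference, and compound 4 cannot be ranked against compound 3 or compound 1. The step from compound 2 to compound 4 cannot be read, as compound 2 stands only as a limit of the assay: the limit of < 100000 nM in this assay, at which 1 of the 4 values shown sits.

Going by these compounds, every readable comparison at this place stays within the scatter, so it remains open whether any group there can shift the number beyond it, for example an amine or a carboxylic acid on the aromatic ring, or a longer chain in place of that ring. The shared core stays the same across all four compounds, so these results say nothing about changes made anywhere else in the molecule.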